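The source may hold more compounds than are shown below. What is called first, only, known or untested is meant among the compounds shown, and "the series" means these compounds.

Measured so far: compound 1 `O=C1/C(=C/c2ccc(F)cc2)CCC/C1=C\c1ccccc1[N+](=O)[O-]`, 1870 nM in a functional assay on MOLT-4 cells (Homo sapiens) for cytotoxicity, with a stated time of 72 h; on this read-out higher numbers stand for weaker inhibition and lower numbers for stronger inhibition; compound 2 `Cc1ccc(/C=C2\CCC/C(=C\c3ccccc3[N+](=O)[O-])C2=O)cc1`, 7520 nM in this assay.

Compound 2 stands highest of the two numbers, its nearest neighbour being compound 1. The one step shown, a 4.0-fold higher number from compound 1 to compound 2 (0.60 log units; beyond the scatter), bears on the next change. Compound 3 `O=C1/C(=C/c2ccccc2)CCC/C1=C\c1ccccc1[N+](=O)[O-]` differs from compound 2 by hydrogen in place of methyl on an aromatic carbon. Because a 4.0-fold higher number from compound 1 to compound 2 (0.60 log units; beyond the scatter) accompanied fluoro giving way to methyl, taking the methyl away is expected to undo part of that rise, though hydrogen is not fluoro, so a full return is not expected. The expected step is a 2.1-fold lower number from compound 2 to compound 3 (0.33 log units; beyond the scatter). Compound 3 is estimated at 3500 nM, between 1300 nM and 9000 nM.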

Compound 3, half-maximal inhibitory concentration in the MOLT-4 assay: 1480 nM
Estimate against measurement, compound 3: 2.4-fold (0.37 log units) above, and the stated range covers the measured number.
By their numbers in the MOLT-4 assay, from the lowest: compounds 3 and 1 (each within the scatter of the next); then compound 2.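

In the MOLT-4 assay hydrogen in place of methyl on the aromatic carbon gives a 5.1-fold lower number from compound 2 to compound 3 (0.71 log units; beyond the scatter) and hydrogen in place of fluoro gives a 1.3-fold lower number from compound 1 to compound 3 (0.10 log units; within the scatter) at the same place, so among these three groups the methyl alone stands apart. In a physicochemical assay for lipophilicity (a higher number here means a more lipophilic compound, a lower number a more polar compound), compound 2 gives 4.86 and compound 3 gives 4.86 on the partition coefficient, so these two compounds part in the cytotoxicity read-out only. Nothing available gives a cause for this step.

Going by these compounds, whether a methoxy group or an amine on this aromatic carbon would follow the methyl or the fluoro stays open.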